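Chain hydroxylation in a prenylated hydroquinone series

The source may hold more compounds than are shown below. What is called first, only, known or untested is meant among the compounds shown, and "the series" means these compounds.

Measured compounds:
compound 1, `CC(=O)O[C@H](CC/C(C)=C/CC/C(C)=C/CC1=CC(=O)C(C)=CC1=O)[C@@](C)(O)CCC=C(C)C`: 31400 nM
compound 2, `CC(C)=CCC/C(C)=C/CC/C(C)=C/CC[C@](C)(O)/C=C\c1cc(O)c(C)cc1O`: > 48500 nM

In a functional assay on MDA-MB-231 cells (Homo sapiens) for cytotoxicity, read by MTT assay, with a stated time of 6 days (on this read-out higher numbers stand for weaker inhibition and lower numbers for stronger inhibition), compound 1 gives 31400 nM. Compound 2 reports only a limit in this assay, > 48500 nM, so no numerical value is known for it. This is seen in the limit of > 48500 nM in this assay, at which 1 of the 2 values shown sits, where compound 2 is the one that sits at that limit. Compound 3, `CC(C)=CCC/C(C)=C/[C@@H](O)C/C(C)=C/CC[C@](C)(O)/C=C\c1cc(O)c(C)cc1O`, is not yet measured. It differs from compound 2 by hydroxy in place of hydrogen on a saturated chain carbon bound to a double-bonded chain carbon and a saturated chain carbon. For the measured compounds named here, no step between two measured compounds is available here to guide the size of this change, and nothing measured ascribes any effect to it. The step expected is an at least 1.0-fold lower number from compound 2 to compound 3 (0.03 log units; that floor lies within the scatter), small and within the scatter, since compound 2 itself is only known as a limit. For compound 3 the estimate in this assay is 45000 nM, with a range from 15000 nM to 70000 nM, and a real chance that this assay again reports only a limit for compound 3.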

Compound 3, half-maximal inhibitory concentration: > 46700 nM
Compound 3 gave a limit, no number (the forecaster's own chance of this, stated with the estimate: 60%); middle value at least 1.0-fold (0.01 log units) away from the limit.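

For the compounds shown here, compound 2 and compound 3 both stand as limits, not numbers, in this assay, and no step between them can be read. Left open is whether hydroxy in place of hydrogen on a saturated chain carbon bound to a double-bonded chain carbon and a saturated chain carbon changes the read-out at all.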